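The source may hold more compounds than are shown below. What is called first, only, known or untested is meant among the compounds shown, and "the series" means these compounds.

Compound 2 `CNC(=O)c1cc(Oc2ccc3cc(C(=O)OC)sc3c2)ccn1` sets the starting point in an ADME assay on HeLa cells (Homo sapiens) for cytotoxicity, read by MTT assay, with a stated time of 2 days (on this read-out higher numbers stand for lower toxicity in this test and lower numbers for higher toxicity in this test), where compound 2 gives 68300 nM. Compound 1 `CCOC(=O)c1cc2ccc(Oc3ccnc(C(=O)NC)c3)cc2s1` carries one more carbon on its ester. In this assay compound 1 gives > 100000 nM, and that figure is a limit of the assay rather than a number (the limit of > 100000 nM in this assay, at which 1 of the 3 values shown sits). The change from compound 2 to compound 1 is methyl in place of hydrogen on a saturated chain carbon bound to an oxygen next to a carbonyl group, and it produced an at least 1.4-fold higher number from compound 2 to compound 1 (0.16 log units; that floor lies within the scatter).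

Compound 3 `CNC(=O)c1cc(Oc2ccc3ccc(C(=O)OC(C)C)cc3c2)ccn1` rests on a different core; the difference between the core of compound 3 and the core of compound 2 is not broken down here. In this assay compound 3 gives 8700 nM, the lowest of the two numbers on hand.

Compound 4 `CCC(C)OC(=O)c1ccc2ccc(Oc3ccnc(C(=O)NC)c3)cc2c1` is not yet measured. It differs from compound 3 by methyl in place of hydrogen on a saturated chain carbon, two bonds along the chain from an oxygen next to a carbonyl group. This is the same kind of change as that from compound 2 to compound 1, though the place is not the same: there the carbon was bound to an oxygen next to a carbonyl group, here it sits two bonds along the chain from that oxygen. Because the earlier change gave an at least 1.4-fold higher number from compound 2 to compound 1 (0.16 log units; that floor lies within the scatter), a step of roughly a 1.1-fold higher number from compound 3 to compound 4 (0.06 log units; within the scatter) is expected here. In this assay compound 4 is estimated to give 10000 nM, within 3000 nM to 40000 nM.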

Compound 4, half-maximal cytotoxic concentration: 9000 nM
For compound 4 the middle estimate is 1.1-fold (0.05 log units) above the measured one; low and high end bracket the measured number.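

The added methyl gives a 1.0-fold higher number from compound 3 to compound 4 (0.01 log units; within the scatter), so in this assay compound 3 and compound 4 cannot be told apart. Set beside the earlier step, the change reads as follows on the two cores: the same change on two cores in this assay, an at least 1.4-fold higher number (0.16 log units; that floor lies within the scatter) from compound 2 to compound 1 and a 1.0-fold higher number (0.01 log units; within the scatter) from compound 3 to compound 4; the limit leaves it open whether they differ Compound 1 sits at a limit of the assay and not at a number, so the two steps show neither that the change carries over unaltered from one core to the other nor that it behaves differently on each.

The compounds shown leave open how a longer chain or a carboxylic acid in place of these esters would read in this assay. Going by these compounds, the place of the added methyl on the chain is also not the same in the two pairs, so it remains open how the change would compare on both cores with the methyl at a single place.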